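A few compounds are considered here, and "the series" means these few. Any claim that something is new, unique, unknown or untested is made for them only; others in the source may bear on it.

Compound 2 `C=C(C)C(=O)Nc1cc2c(N3CCc4ccccc43)ncnc2cc1O[C@@H]1CCOC1` is one of three compounds tested in a functional assay on PC-3 cells (Homo sapiens) for antiproliferative activity, read by MTT assay, with a stated time of 72 h; a higher number here means a weaker inhibitor, a lower number a stronger inhibitor; in this assay compound 2 gives 4910 nM. Compound 1 `C=C(C)C(=O)Nc1cc2c(N3CCc4ccccc43)ncnc2cc1OC` gives 4830 nM, and compound 3 `CC(C)=CC(=O)Nc1cc2c(N3CCCc4ccccc43)ncnc2cc1O[C@@H]1CCOC1` gives 9020 nM. All three numbers lie within the usual scatter of one another, so compound 2 sits together with the others rather than apart from them. Among the measured compounds shown here, the only measured single-site step, a 1.0-fold higher number from compound 1 to compound 2 (0.01 log units; within the scatter), concerns a different part of the molecule and was flat. Compound 4 `O=C(/C=C/CN1CCCCC1)Nc1cc2c(N3CCc4ccccc43)ncnc2cc1O[C@@H]1CCOC1` differs from compound 2 by 3-(piperidin-1-yl)prop-1-en-1-yl in place of 1-methylethenyl on a carbonyl carbon. For the measured compounds named here, no measured step touches this part of the molecule, so there is no direct guide. Compound 4 is therefore expected to show a 1.4-fold lower number from compound 2 to compound 4 (0.15 log units; within the scatter), a step within the scatter. For compound 4 the estimate is 3500 nM, ranging from 1200 nM to 10000 nM.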

Compound 4, half-maximal inhibitory concentration: 4510 nM
For compound 4 the middle estimate is 1.3-fold (0.11 log units) below the measured one; low and high end bracket the measured number.
By their numbers in this assay, from the lowest: compounds 4, 1, 2 and 3 (each within the scatter of the next).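

Replacing 1-methylethenyl with 3-(piperidin-1-yl)prop-1-en-1-yl on the carbonyl carbon gives a 1.1-fold lower number from compound 2 to compound 4 (0.04 log units; within the scatter) in this assay despite the added six-membered ring. Among the compounds shown here, this position, which no earlier step touched, therefore takes a group of 9 heavy atoms in place of 3 without a readable change in this cell-based read-out. No measurement shown explains this flat result. The compounds shown leave open whether a dimethylamino group or a morpholine ring in place of the piperidine ring would also leave the number unchanged.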